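The source may hold more compounds than are shown below. What is called first, only, known or untested is meant among the compounds shown, and "the series" means these compounds.

Solubility in the series: compound 1 `C=CC(=O)Nc1cccc(-c2nc3ccccc3s2)c1` gives 180 nM in a physicochemical assay for solubility, in phosphate buffer, measured as kinetic solubility, with a stated time of 18 h, at pH 7.4 (on this read-out higher numbers stand for higher solubility and lower numbers for lower solubility), compound 2 `C=C(C)C(=O)Nc1cccc(-c2nc3ccccc3s2)c1` gives 420 nM, and compound 3 `O=C(CCl)Nc1cccc(-c2nc3ccccc3s2)c1` gives 1000 nM, the highest of the three numbers; the steps were a 2.3-fold higher number from compound 1 to compound 2 (0.37 log units; beyond the scatter), a 5.6-fold higher number from compound 1 to compound 3 (0.74 log units; beyond the scatter) and a 2.4-fold higher number from compound 2 to compound 3 (0.38 log units; beyond the scatter). Compound 4 `O=C(Nc1cccc(-c2nc3ccccc3s2)c1)c1cnccc1Cl` differs from compound 3 by 4-chloropyridin-3-yl in place of chloromethyl on a carbonyl carbon. For the measured compounds named here, none of the measured steps exchanges a chain for an aromatic ring, so no step bears directly on this change; all three were modest, and the direction of the present step is not settled by them. A number for compound 4 is expected near or somewhat under compound 3, with a 1.7-fold lower number from compound 3 to compound 4 (0.22 log units; within the scatter) carrying wide uncertainty. The estimate for compound 4 in this assay is 600 nM, ranging from 150 nM to 2500 nM.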

Compound 4, solubility: 320 nM
Beside the measured number, compound 4's estimate is 1.9-fold (0.27 log units) above it; the range from low to high includes it.
By their numbers in this assay, from the lowest: compounds 1, 4 and 2 (each within the scatter of the next, the first and the last beyond it); then compound 3.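

In this assay, 4-chloropyridin-3-yl in place of chloromethyl on the carbonyl carbon gives a 3.1-fold lower number from compound 3 to compound 4 (0.49 log units; beyond the scatter), so the aromatic ring does not match chloromethyl here. Against the open-chain groups the ring gives a 1.3-fold lower number from compound 2 to compound 4 (0.12 log units; within the scatter) for 1-methylethenyl and a 1.8-fold higher number from compound 1 to compound 4 (0.25 log units; within the scatter) for vinyl, both within the scatter, so compound 3 alone stands apart. No measurement at hand accounts for these numbers.

Still open, going by these compounds, is what the ring nitrogen and the ring chlorine each contribute. Also open, on these data alone, is where a plain phenyl or an aminomethyl group on the carbonyl carbon would fall.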